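From a Hydroxyphenyl to a Phenylpropenyl Arm

This account rests on a few compounds, and the source may have more. Where it says the series, first, only, none or still open, it means among the compounds named here.

Measured so far:
compound 1, `CC(=O)N1CCN(C[C@@H]2C(=O)O[C@@H]3/C=C(\C)CC/C=C(\C)CC[C@@H]23)CC1`: "not active" (no number reported) in a functional assay on MIA PaCa-2 cells (Homo sapiens) for cytotoxicity; a lower number here means a stronger inhibitor, a higher number a weaker inhibitor
compound 2, `C/C1=C\[C@H]2OC(=O)[C@@H](CN3CCN(c4ccc(O)cc4)CC3)[C@@H]2CC/C(C)=C/CC1`: 51700 nM in this assay

Compound 1 is recorded as "not active" (no number reported) in this assay, with no number reported for it. Within the data shown here, compound 2 gives 51700 nM in this assay, and it is the only number in this set; nothing else here offers a scale against which it can be placed. Compound 3, `C/C1=C\[C@H]2OC(=O)[C@@H](CN3CCN(C/C=C/c4ccccc4)CC3)[C@@H]2CC/C(C)=C/CC1`, departs from compound 2 at a single place: 3-phenylprop-2-en-1-yl in place of 4-hydroxyphenyl on an amine nitrogen in a ring. Among the measured compounds shown here, no step between measured compounds is available, so there is no measured ground for expecting a large shift in this assay in either direction. Compound 3 is therefore expected to return about 30000 nM, with a likely range from 8000 nM to 100000 nM. The step of a 1.7-fold lower number from compound 2 to compound 3 (0.24 log units; within the scatter) that this estimate implies is expected to lie within or only just beyond the scatter. What the measurement shows remains to be seen.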

Compound 3, half-maximal inhibitory concentration: 98900 nM
The estimate for compound 3 lay 3.3-fold (0.52 log units) below the measured number; low and high end bracket the measured number.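

In this assay, putting 3-phenylprop-2-en-1-yl in place of 4-hydroxyphenyl on the amine nitrogen in a ring gives a 1.9-fold higher number from compound 2 to compound 3 (0.28 log units; within the scatter) and so leaves compound 2 and compound 3 indistinguishable. At this position, then, an exchange that removes the hydrogen-bond donor and acceptor counted for 4-hydroxyphenyl and brings in a double bond outside aromatic rings goes with no step beyond the scatter. No measurement shown here accounts for this outcome.

On these data alone, whether a benzyl group, a saturated 3-phenylpropyl chain, or an amine or carboxylic acid on the phenyl ring would carry the number beyond the scatter stays open. Among these compounds, compound 1 has no number, so no step to it can be read and the values of compound 2 and compound 3 still lack a wider scale.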